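This account rests on a few compounds, and the source may have more. Where it says the series, first, only, none or still open, it means among the compounds named here.

Compound 1, with structure `Cc1nc(NC(=O)NCc2ccccc2)c2nn(-c3ccccc3)cc2n1`, is the reference point here. In an assay on CHO cells for displacement of a labelled ligand from adenosine receptor A1 (Homo sapiens), read by scintillation counting, with a stated time of 120 min, tested at 1 uM (a lower number here means less inhibition, a higher number more inhibition at the concentration tested (going by the name of the read-out)), compound 1 gives 26%, the highest of the three numbers measured. Among the compounds with values here, compound 3, `COc1ccc(-n2cc3nc(C)nc(NC(=O)NCc4ccccc4)c3n2)cc1`, gives 8%, and the single change from methoxy in place of hydrogen on an aromatic carbon brings a number 18 percentage points lower from compound 1 to compound 3 (beyond the scatter). Compound 2, `COc1ccc(-n2cc3nc(-c4ccccc4)nc(NC(C)=O)c3n2)cc1`, gives 1%; it differs from compound 1 in more than one place, so only its bare value can be set beside the others.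

Compound 4, `Cc1nc(NC(=O)c2ccncc2)c2nn(-c3ccccc3)cc2n1`, differs from compound 1 by pyridin-4-yl in place of benzylamino on a carbonyl carbon. Within the data shown here, none of the measured steps touches this part of the molecule, so there is no direct guide. Among the measured compounds shown here, the only hint is that compound 2, which also carries a carbonyl without the benzylamino piece, gives a low value, though its other change clouds that reading. The step of a number 14 percentage points lower from compound 1 to compound 4 (beyond the scatter) is therefore expected to be a modest loss, with wide uncertainty. For compound 4 the estimate in this assay is 12%, within 0% to 35%.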

Compound 4, a percentage reported as inhibition, at one concentration (the size of the read-out at that concentration, not a potency): 12%
Compound 4: middle estimate and measured number agree at the digits printed; the measured number falls inside the stated range.
By their numbers in this assay, from the lowest: compounds 2, 3 and 4 (each within the scatter of the next, the first and the last beyond it); then compound 1.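

Within the data shown here, at the carbonyl carbon, which no earlier step had touched, pyridin-4-yl in place of benzylamino brings a number 14 percentage points lower from compound 1 to compound 4 (beyond the scatter) in this assay, so this part of the molecule does affect the read-out. The swap alters several things at once: the group that leaves has one hydrogen-bond donor and an all-carbon aromatic ring, while the group that enters has one hydrogen-bond acceptor, a ring with one hetero atom and fewer heavy atoms. No separate measurement bears on which of these differences matters.

As far as these compounds go, it remains open whether the drop follows from the ring nitrogen of pyridin-4-yl or from the absence of the benzylamino group. A phenyl group on the same carbonyl carbon would address the first possibility, and a methylamino group there would address the second.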